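Moving the Fluorine on the Phenyl of a Succinimide Amide

The compounds below may be only part of what the source reports. "The series", "measured", "known", "first", "only" and "open" are said of these compounds alone.

Compound 3 `CC(C(=O)N1CCN(c2ccc(F)cc2)CC1)N1C(=O)CCC1=O` was examined in a functional assay on the whole organism (strain Swiss) with Mus musculus as the target, in the maximal electroshock model, with a stated time of 2 h, at a dose of 100 mg/kg by the intraperitoneal route; a lower number here means a weaker effect, a higher number a stronger effect of the compound at the dose given. There compound 3 gives 0%, level with compound 1 `CC(C(=O)N1CCN(c2cccc(Cl)c2)CC1)N1C(=O)CCC1=O`, which gives 0%, and with compound 2 `CC(C(=O)N1CCN(c2ccc(Cl)cc2)CC1)N1C(=O)CCC1=O`, which gives 0%. Compound 4 `CC(C(=O)N1CCN(c2cccc(F)c2)CC1)N1C(=O)CCC1=O` differs from compound 3 by 3-fluorophenyl in place of 4-fluorophenyl on an amine nitrogen in a ring. Going by the values given here, three measured steps bear on this change: no change at the digits printed from compound 1 to compound 2 (within the scatter), no change at the digits printed from compound 1 to compound 3 (within the scatter) and no change at the digits printed from compound 2 to compound 3 (within the scatter). Each exchanged one halophenyl for another on the same nitrogen, and none moved the activity beyond the scatter. Accordingly no shift beyond the scatter is expected for no change at the digits printed from compound 3 to compound 4 (within the scatter) in this assay. Compound 4 is therefore estimated to give 0% in this assay, with a range from 0% to 10%.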

Compound 4, a percentage reported as activity, at one dose (the size of the read-out at that dose, not a potency): 0%
Beside the measured number, compound 4's estimate shows no gap at the digits printed; the measured number falls inside the stated range.
By their numbers in this assay, from the lowest: compounds 1, 2, 3 and 4 (each within the scatter of the next).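

With fluoro, as with chloro before it, the place of the halogen on the phenyl now shows no effect: 3-fluorophenyl in place of 4-fluorophenyl gives no change at the digits printed from compound 3 to compound 4 (within the scatter). Changing both place and halogen at once, 3-fluorophenyl in place of 4-chlorophenyl, gives no change at the digits printed from compound 2 to compound 4 (within the scatter). Fluoro in place of chloro now reads alike in a second pair, with no change at the digits printed from compound 1 to compound 4 (within the scatter): the same change on two cores in this assay, no change at the digits printed (within the scatter) from compound 2 to compound 3 and no change at the digits printed (within the scatter) from compound 1 to compound 4, 0 percentage points apart, within the scatter of two such steps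

Since all four compounds read the same, they cannot show whether the place or the kind of halogen could matter in a compound with measurable activity. From the compounds shown here alone, whether a methoxy or trifluoromethyl group on the phenyl would give any activity stays open.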